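Ethoxy to methoxy: from compound 2 to compound 4

The compounds below may be only part of what the source reports. "The series", "measured", "known", "first", "only" and "open" are said of these compounds alone.

In an ADME assay on L929 cells (Mus musculus) for cytotoxicity, read by CCK-8 assay, with a stated time of 48 h, tested at 100 uM (on this read-out lower numbers stand for a stronger effect and higher numbers for a weaker effect at the one concentration tested), compound 2 `CCOc1ccc(S(=O)(=O)N2CCN(c3cccc(C)c3)CC2)cc1S(=O)(=O)N1CCN(c2cccc(C)c2)CC1` gives 33.3%, the second highest of the three numbers measured. Compound 3 `CCOc1ccc(S(=O)(=O)N2CCN(Cc3ccccc3)CC2)cc1S(=O)(=O)N1CCN(Cc2ccccc2)CC1` gives 22.2%, the nearest number, a difference beyond the scatter, and compound 1 `COc1ccc(S(=O)(=O)N2CCN(c3ccccc3F)CC2)cc1S(=O)(=O)N1CCN(c2ccccc2F)CC1` gives 66.7%, the furthest number, also beyond the scatter. Compound 4 `COc1ccc(S(=O)(=O)N2CCN(c3cccc(C)c3)CC2)cc1S(=O)(=O)N1CCN(c2cccc(C)c2)CC1` has not been measured in this assay. It differs from compound 2 by hydrogen in place of methyl on a saturated chain carbon bound to an oxygen on an aromatic ring. Within the data shown here, no measured pair shows this change alone, and compound 1 carries methoxy but differs from compound 2 elsewhere as well, so the direction rests on little. The step of a number 6.7 percentage points higher from compound 2 to compound 4 (within the scatter) is expected to be small, within or only just beyond the scatter, toward a weaker effect. Compound 4 is estimated at 40%, with a range from 22% to 62%.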

Compound 4, a percentage reported as activity, at one concentration (the size of the read-out at that concentration, not a potency): 66.7%
Compound 4: the middle estimate sits 26.7 percentage points below what was measured, and the stated range ends below it.
By their numbers in this assay, from the lowest: compound 3; then compound 2; then compounds 1 and 4 (each within the scatter of the next).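

Ethoxy to methoxy in this assay gives a number 33.4 percentage points higher from compound 2 to compound 4 (beyond the scatter), the first reading of this change alone. Hydrogen in place of methyl at this position, a loss of one carbon, is enough to give a large step toward a weaker effect, which compounds 1, 2 and 3, differing in more than one place, could not show. No measurement shown here accounts for the size of this step.

Going by these compounds, whether a longer chain such as propoxy, or a hydroxyl in place of the alkoxy group, would continue this direction remains open. Also open, on these data alone, is whether the step holds with the other end groups of compound 1 and compound 3.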